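Moving the halogen and swapping it for a nitrile on the phenyl ring

The compounds below may be only part of what the source reports. "The series", "measured", "known", "first", "only" and "open" are said of these compounds alone.

Of the compounds shown here, three sharing one core have been tested in a functional assay on PANC-1 cells (Homo sapiens) for inhibition, read by MTT assay, with a stated time of 24 h; a lower number here means a stronger inhibitor, a higher number a weaker inhibitor. Compound 1 `CC1(C)[C@H]2CC[C@]1(C)N(Cc1cn(-c3ccccc3Br)nn1)C(=O)C2` gives 280 nM, compound 2 `CC1(C)[C@H]2CC[C@]1(C)N(Cc1cn(-c3cccc(O)c3)nn1)C(=O)C2` gives 280 nM, and compound 3 `CC1(C)[C@H]2CC[C@]1(C)N(Cc1cn(-c3cccc(Br)c3)nn1)C(=O)C2` gives 90 nM. Compound 3 stands lowest of the three, with a 3.1-fold lower number from compound 1 to compound 3 (0.49 log units; beyond the scatter) and a 3.1-fold lower number from compound 2 to compound 3 (0.49 log units; beyond the scatter), while compound 1 and compound 2 sit within the scatter of each other, as no change at the digits printed from compound 1 to compound 2 (within the scatter).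

Compound 4 `CC1(C)[C@H]2CC[C@]1(C)N(Cc1cn(-c3ccc(C#N)cc3)nn1)C(=O)C2` has not yet been measured. It differs from compound 3 in one place: 4-cyanophenyl in place of 3-bromophenyl on an aromatic nitrogen. Among the measured compounds shown here, no measured step replaces a bromo group with a cyano group, so none bears on this change directly. The two steps that lead to compound 3 both concern the same phenyl ring: moving the bromo from the 2-position to the 3-position, and exchanging hydroxy for bromo, each gave a modest change of the size stated above. Leaving the 3-bromophenyl that gave compound 3 its lowest number is therefore expected to cost a modest amount, and a 2.2-fold higher number from compound 3 to compound 4 (0.35 log units; beyond the scatter) is the estimated step. Compound 4 is expected to give 200 nM, with a range from 70 nM to 600 nM.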

Compound 4, half-maximal inhibitory concentration: 250 nM
For compound 4 the middle estimate is 1.3-fold (0.10 log units) below the measured one, within the range that was stated.
By their numbers in this assay, from the lowest: compound 3; then compounds 4, 1 and 2 (each within the scatter of the next).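

The change from 3-bromophenyl to 4-cyanophenyl gives back the advantage seen for compound 3 in this assay (a 2.8-fold higher number from compound 3 to compound 4 (0.44 log units; beyond the scatter)), while the nitrile-bearing compound cannot be separated from either of the two other compounds (a 1.1-fold lower number from compound 2 to compound 4 (0.05 log units; within the scatter); a 1.1-fold lower number from compound 1 to compound 4 (0.05 log units; within the scatter)). Among the four groups on this aromatic nitrogen, only the 3-bromophenyl of compound 3 now stands apart, whereas 2-bromophenyl, 3-hydroxyphenyl and 4-cyanophenyl form a single level within the scatter. No measurement at hand accounts for this result.

Compound 4 differs from compound 3 in both the group and its place on the phenyl ring, so the compounds shown leave open which of the two sets the step. Going by these compounds, what an amine or a carboxylic acid on this phenyl ring would give also remains open.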